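The source may report more compounds than this note shows. Statements on the series, on what has been measured and on what is new or still open speak of the compounds shown alone.

Three compounds have been measured in an assay on HeLa cells for displacement of a labelled ligand from adenosine receptor A3 (Homo sapiens), read by scintillation counting, with a stated time of 180 min, tested at 10 uM; a lower number here means less inhibition, a higher number more inhibition at the concentration tested (going by the name of the read-out):

Compound 1, `N=c1oc2ccc(Br)cc2cc1C(=O)NC1CCCCC1`, gives 8%.
Compound 2, `CCC(CO)NC(=O)c1cc2cc(Br)ccc2oc1=N`, gives 24%.
Compound 3, `N=c1oc2ccc(Br)cc2cc1C(=O)NC1CCCC1`, gives 0%.

Compound 3 stands at the bottom of these three numbers. Its nearest neighbour is compound 1, with a step of a number 8 percentage points lower from compound 1 to compound 3 (within the scatter), so the two cannot be told apart. Its furthest neighbour is compound 2, with a step of a number 24 percentage points lower from compound 2 to compound 3 (beyond the scatter), a modest but genuine drop. Going by the values given here, the one change to compound 4, `N=c1oc2ccc(Br)cc2cc1C(=O)NCCCO`, is 3-hydroxypropyl in place of cyclopentyl on an amide-type nitrogen.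

Among the compounds with values here, two measured steps bear on this. The step of a number 24 percentage points lower from compound 2 to compound 3 (beyond the scatter) shows that trading an open chain bearing a hydroxyl for cyclopentyl lowered the read-out, and the step of a number 16 percentage points higher from compound 1 to compound 2 (beyond the scatter) shows the same open chain raising it against cyclohexyl. Compound 4 returns to an open chain with a hydroxyl, so a modest rise beyond the scatter is expected, with the step of a number 15 percentage points higher from compound 3 to compound 4 (beyond the scatter). For compound 4 the estimated value is 15%, with a likely range from 0% to 35%.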

Compound 4, a percentage reported as inhibition, at one concentration (the size of the read-out at that concentration, not a potency): 17%
Compound 4: middle estimate off by 2 percentage points, on the low side; low and high end bracket the measured number.
By their numbers in this assay, from the lowest: compounds 3, 1, 4 and 2 (each within the scatter of the next, the first and the last beyond it).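

In this assay, 3-hydroxypropyl on the amide-type nitrogen also separates from cyclopentyl, with a number 17 percentage points higher from compound 3 to compound 4 (beyond the scatter), so this separation is not confined to the branched 1-(hydroxymethyl)propyl of compound 2. The two hydroxyl chains cannot be told apart, with a number 7 percentage points lower from compound 2 to compound 4 (within the scatter), yet the rise over cyclohexyl seen for compound 2 does not carry over clearly, with a number 9 percentage points higher from compound 1 to compound 4 (within the scatter) leaving compound 4 unresolved from that ring. No supporting evidence is available to explain these differences.

The hydroxyl and the open chain enter together in compound 4, so the compounds shown leave open which of them accounts for the step from cyclopentyl, a question a plain propyl chain would address. As far as these compounds go, how an amine in place of the hydroxyl, or a longer chain, would read also remains open.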